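The source may hold more compounds than are shown below. What is called first, only, known or untested is meant among the compounds shown, and "the series" means these compounds.

Measured so far in an ADME assay on NIH3T3 cells (Mus musculus) for cytotoxicity, read by MTT assay, with a stated time of 24 h; a lower number here means a stronger inhibitor, a higher number a weaker inhibitor: compound 1 `O=C(CSc1nnnn1-c1ccccc1)N/N=c1/scc(-c2ccc(Cl)cc2)n1-c1ccccc1` gives 313 ug/mL; compound 2 `O=C(CSc1nnnn1-c1ccccc1)N/N=c1/scc(-c2ccc([N+](=O)[O-])cc2)n1-c1ccccc1` gives 14.3 ug/mL; compound 3 `Cn1nnnc1SCC(=O)N/N=c1/scc(-c2ccc([N+](=O)[O-])cc2)n1-c1ccccc1` gives 167 ug/mL.

The unmeasured compound 4 `Cn1nnnc1SCC(=O)N/N=c1/scc(-c2ccc(Cl)cc2)n1-c1ccccc1` differs from compound 3 by chloro in place of nitro on an aromatic carbon. The same change has been made once before among these compounds, between compound 2 and compound 1, where it reads chloro in place of nitro on an aromatic carbon and gave a 22-fold higher number from compound 2 to compound 1 (1.34 log units; beyond the scatter). The two cores on which the change sits are not the same: compound 3 differs from compound 2 by methyl in place of phenyl on an aromatic nitrogen, a step of a 12-fold higher number from compound 2 to compound 3 (1.07 log units; beyond the scatter). Compound 3 and compound 1 stand within the scatter of each other.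

For the measured compounds named here, whether the change from compound 3 to compound 4 repeats the earlier step is uncertain, as only one prior instance exists and it rests on a different core. Because compound 3 already gives 167 ug/mL, a number near the high end of what this assay has reported here, compound 4 is expected to move by a 3.0-fold higher number from compound 3 to compound 4 (0.48 log units; beyond the scatter), a smaller step than that seen from compound 2 to compound 1. Compound 4 is estimated at 500 ug/mL, with a likely range of 200 ug/mL to 1500 ug/mL.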

Compound 4, half-maximal inhibitory concentration: 40 ug/mL
Estimate against measurement, compound 4: 13-fold (1.10 log units) above, and the stated range ends above it.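

In this assay chloro in place of nitro gives a 4.2-fold lower number from compound 3 to compound 4 (0.62 log units; beyond the scatter) and methyl in place of phenyl on an aromatic nitrogen gives a 7.8-fold lower number from compound 1 to compound 4 (0.89 log units; beyond the scatter) on the cores that carry them here. Neither change moves from one core to the other as a fixed step, and the chloro for nitro change even reverses its direction: the same change on two cores in this assay, a 22-fold higher number (1.34 log units; beyond the scatter) from compound 2 to compound 1 and a 4.2-fold lower number (0.62 log units; beyond the scatter) from compound 3 to compound 4, 91-fold (1.96 log units) apart, beyond the scatter of two such steps. These four compounds show only that the outcome of each change depends on the group at the other place, not why it does so or how it would behave on any further core, and the methyl for phenyl change gives the same reading: the same change on two cores in this assay, a 12-fold higher number (1.07 log units; beyond the scatter) from compound 2 to compound 3 and a 7.8-fold lower number (0.89 log units; beyond the scatter) from compound 1 to compound 4, 91-fold (1.96 log units) apart, beyond the scatter of two such steps.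

The compounds shown leave open whether a fluoro, a methoxy or an amine on the same aromatic carbon would follow the chloro or the nitro compounds. They also leave open how an ethyl or a longer chain on the aromatic nitrogen would compare with methyl and phenyl.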